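Trimming the saturated chain of compound 2

A few compounds are considered here, and "the series" means these few. Any claim that something is new, unique, unknown or untested is made for them only; others in the source may bear on it.

In a functional assay on NCI-H460 cells (Homo sapiens) for antiproliferative activity, read by sulforhodamine B assay, with a stated time of 48 h (on this read-out lower numbers stand for stronger inhibition of growth and higher numbers for weaker inhibition of growth), compound 1 `CCCCCC[C@@H](O)C/C=C\CCCCCCCC(=O)N[C@@H](C)c1ccccc1` gives 8.3 ug/mL. Compound 2 `CCCCCCCCCCCCCCCCCC(=O)N1CCOCC1` gives 53.1 ug/mL, the higher number of the pair, with a gap beyond the usual scatter. For the measured compounds named here, only these two values are available, and the two structures differ in several places, so no measured pair shows what a change in the saturated chain alone does.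

Compound 3 `CCCCCCCCCCCCCCCC(=O)N1CCOCC1` differs from compound 2 at one place, with hydrogen in place of ethyl on a saturated chain carbon, ten or more bonds along the chain from a carbonyl carbon. The change lies far along the chain from the carbonyl carbon, so only a small shift is expected. The expected step of a 1.3-fold lower number from compound 2 to compound 3 (0.10 log units; within the scatter) leans slightly toward a lower number and stays within the scatter. For compound 3 the estimated value is 42 ug/mL, with an expected range from 18 ug/mL to 95 ug/mL.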

Compound 3, concentration for 50% growth inhibition: 34.1 ug/mL
The estimate for compound 3 lay 1.2-fold (0.09 log units) above the measured number; measured number inside the range.
By their numbers in this assay, from the lowest: compound 1; then compounds 3 and 2 (each within the scatter of the next).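

In this assay, for the compounds shown here, hydrogen in place of ethyl on a saturated chain carbon, ten or more bonds along the chain from a carbonyl carbon, gives a 1.6-fold lower number from compound 2 to compound 3 (0.19 log units; within the scatter) and provides the first comparison at a single place. The step lies within the scatter, so this read-out does not separate the two chain lengths of compound 2 and compound 3, and the ethyl at this place shows no measurable contribution. No measurement in hand bears on why the step is this size.

Still open, as far as these compounds go, is whether a much shorter chain, a longer chain, or a carboxylic acid at the chain end would move the number beyond the scatter. Also open, from the compounds shown here alone, is what the amide part of compound 1 would give when placed alone on this saturated chain.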